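Chain-extended methoxyalkylamidines: carboxy removal on the amine-bearing carbon

This account rests on a few compounds, and the source may have more. Where it says the series, first, only, none or still open, it means among the compounds named here.

Three compounds have numbers in an assay on isolated protein for inhibition of Nitric oxide synthase, inducible (Homo sapiens), read by spectrophotometry, using NADPH, tested at 1 mM, in the presence of a further agent that is not named here; a lower number here means less inhibition, a higher number more inhibition at the concentration tested (going by the name of the read-out). Compound 1 `COCC(=N)NCCCCN` gives 42%, compound 2 `COCCC(=N)NCCCCN` gives 16%, and compound 3 `COCCCC(=N)NCCC[C@H](N)C(=O)O` gives 26%. Compound 3 sits below compound 1, beyond the scatter, while its gap to compound 2 lies within the scatter. Among the measured compounds shown here, the one measured step, a number 26 percentage points lower from compound 1 to compound 2 (beyond the scatter), concerns the chain between the methoxy and the amidine carbon and is modest.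

Compound 4 `COCCCC(=N)NCCCCN` differs from compound 3 by hydrogen in place of carboxy on a saturated chain carbon bound to an amine nitrogen and a saturated chain carbon. For the measured compounds named here, no measured step touches this change; the only measured pair varies the chain, not the amine-bearing carbon, so it gives no direction. The step from compound 3 to compound 4 is therefore expected to be a number 4 percentage points higher from compound 3 to compound 4 (within the scatter), not clearly beyond the scatter. Compound 4 is expected to give 30%, within 10% to 55%.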

Compound 4, a percentage reported as inhibition, at one concentration (the size of the read-out at that concentration, not a potency): 15%
Beside the measured number, compound 4's estimate is 15 percentage points above it, within the range that was stated.
By their numbers in this assay, from the lowest: compounds 4, 2 and 3 (each within the scatter of the next, the first and the last beyond it); then compound 1.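

In this assay hydrogen in place of carboxy gives a number 11 percentage points lower from compound 3 to compound 4 (beyond the scatter) and so shows that this position, untouched by the earlier pair, carries a change beyond the scatter at this chain length. On the chain side a number 27 percentage points lower from compound 1 to compound 4 (beyond the scatter) stands with a number 1 percentage points lower from compound 2 to compound 4 (within the scatter) and so the fall already reached at compound 2 goes no further at compound 4.

On these data alone, whether a carboxylic ester or an amide at this carbon, or a longer chain on the methoxy side, would read differently stays open. No evidence at hand bears on the reason for these steps.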